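This account rests on a few compounds, and the source may have more. Where it says the series, first, only, none or still open, it means among the compounds named here.

Measured so far:
compound 1, `COc1cc(C(=O)NC2CCN(C)CC2)ccc1Nc1ncc(F)c(NC2CCCC2)n1`: 4500 nM
compound 2, `CN1CCC(NC(=O)c2ccc(Nc3ncc([N+](=O)[O-])c(NC4CCCC4)n3)cc2)CC1`: 5800 nM
compound 3, `CCCNc1nc(Nc2ccc(N3CCN(C)CC3)cc2)ncc1F`: 35000 nM

All three numbers come from a functional assay on HepG2 cells (Homo sapiens) for cytotoxicity, read by MTT assay, with a stated time of 48 h; a lower number here means a stronger inhibitor, a higher number a weaker inhibitor. Compound 2 holds the second highest number of the three. Its nearest neighbour is compound 1, whose number lies within the scatter of the number for compound 2, so no order between these two is claimed. Its furthest neighbour is compound 3, whose higher number lies beyond the scatter, so of that pair compound 3 is the weaker inhibitor.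

Compound 4, `CN1CCC(NC(=O)c2ccc(Nc3ncc(Br)c(NC4CCCC4)n3)cc2)CC1`, has not yet been measured in this assay. Relative to compound 2 the change is bromo in place of nitro on an aromatic carbon. Within the data shown here, no measured pair in the set shows this change, so the size of the step cannot be read from the data. A step not beyond the scatter is expected, with no direction preferred. Compound 4 is therefore estimated at 5000 nM in this assay, with a range from 2000 nM to 15000 nM. The expected step is a 1.2-fold lower number from compound 2 to compound 4 (0.06 log units; within the scatter).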

Compound 4, half-maximal inhibitory concentration: 2400 nM
The estimate for compound 4 lay 2.1-fold (0.32 log units) above the measured number; measured number inside the range.
By their numbers in this assay, from the lowest: compounds 4, 1 and 2 (each within the scatter of the next, the first and the last beyond it); then compound 3.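

In this assay, the position on the aromatic carbon ortho to the cyclopentylamino group and para to a large group now has its first one-place comparison: bromo in place of nitro gives a 2.4-fold lower number from compound 2 to compound 4 (0.38 log units; beyond the scatter). The earlier compounds shown here offered no step at all, whereas this pair shows that the number responds to the group at this position, though the step is modest and rests on this single pair. Nothing measured bears on why the number moves with this change.

Open, going by these compounds, is how other groups at this position, such as chloro, an amine or a nitrile, would stand against compound 2 and compound 4. Also open, on these data alone, is whether the same change gives a similar step when a longer chain replaces the cyclopentylamino group.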